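Bromine at the Benzyl Group: An Untested Variant

The source may report more compounds than this note shows. Statements on the series, on what has been measured and on what is new or still open speak of the compounds shown alone.

Compound 1 `Cc1cccc(Cn2cc(COc3ccc4c(=O)ccoc4c3)nn2)c1` is one of three compounds whose cytotoxicity was determined in a functional assay on HeLa cells (Homo sapiens) for cytotoxicity, read by MTT assay, with a stated time of 48 h; on this read-out higher numbers stand for weaker inhibition and lower numbers for stronger inhibition. In this assay compound 1 gives > 100000 nM, which is a limit of the assay and not a number. Compound 2 `N#Cc1ccc(Cn2cc(COc3ccc4c(=O)ccoc4c3)nn2)cc1` likewise gives > 100000 nM, again a limit. Compound 3 `Cc1ccccc1Cn1cc(COc2ccc3c(=O)ccoc3c2)nn1` gives 15300 nM. Compound 1 therefore stands at the limit of > 100000 nM in this assay, at which 2 of the 3 values shown sit, with no number of its own. The step that the two limits leave unreadable from compound 1 to compound 2 cannot be read, as both compounds sit at the limit of > 100000 nM in this assay, at which 2 of the 3 values shown sit. The steps of an at least 6.5-fold lower number from compound 1 to compound 3 (0.81 log units; beyond the scatter) and an at least 6.5-fold lower number from compound 2 to compound 3 (0.81 log units; beyond the scatter) show that the 2-methylphenyl group brings the number down beyond the scatter.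

Compound 4 `O=c1ccoc2cc(OCc3cn(Cc4ccc(Br)cc4)nn3)ccc12` has not yet been measured in this assay. It differs from compound 1 by 4-bromophenyl in place of 3-methylphenyl on a saturated chain carbon bound to an aromatic nitrogen. Like compound 2 with its 4-cyanophenyl, compound 4 carries a group other than the 2-methylphenyl of compound 3, and the only step that resembles this change, a step that the two limits leave unreadable from compound 1 to compound 2, left both ends at the limit. Compound 4 is therefore expected to give about 100000 nM, between 30000 nM and 300000 nM, with a good chance that the assay again reports only a limit. The estimated step of a number no higher from compound 1 to compound 4 (the limit leaves the size open) is expected to be none beyond the scatter.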

Compound 4, half-maximal inhibitory concentration: > 100000 nM
Compound 4: no number, only a limit; the forecaster's own chance of this, stated with the estimate: 60%; the middle value sits exactly at the limit.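

In this assay, 4-bromophenyl proves to be the third group on a saturated chain carbon bound to an aromatic nitrogen that leaves a compound at a limit rather than a number, so compound 3 now stands apart from three compounds and not two: the limit of > 100000 nM in this assay, at which 3 of the 4 values shown sit. Putting 4-bromophenyl in place of 2-methylphenyl gives an at least 6.5-fold higher number from compound 3 to compound 4 (0.81 log units; beyond the scatter), so the gain seen with compound 3 is lost with this group as it was with 3-methylphenyl and 4-cyanophenyl. The steps linking compound 4 to compound 1 and to compound 2 cannot be read, and nothing separates the 3-methylphenyl, 4-cyanophenyl and 4-bromophenyl groups from one another.

The compounds shown leave open whether the number of compound 3 belongs to 2-methylphenyl alone or would also appear with a 2-bromophenyl group, which would tell the methyl from the bromine at that place. Going by these compounds alone, also open is how a 2-aminophenyl or 2-carboxyphenyl group would read on the same carbon, since compound 3 is the only compound here that gives a number.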